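Compound 2 and the Loss of a Methyl

A few compounds are considered here, and "the series" means these few. Any claim that something is new, unique, unknown or untested is made for them only; others in the source may bear on it.

In a physicochemical assay, read by spectrophotometry, with a stated time of 15 min (on this read-out lower numbers stand for stronger inhibition and higher numbers for weaker inhibition), compound 2 `COc1cc(/C=N/NC(=O)CCCc2nc3ccccc3c(=O)[nH]2)ccc1O` gives 280000000 nM, the weakest inhibition of the three measured compounds and beyond the scatter from both others. Compound 4 `O=C(CCCc1nc2ccccc2c(=O)[nH]1)N/N=C/c1ccc(O)c(O)c1` is related to it by hydrogen in place of methyl on an oxygen on an aromatic ring, so that 4-hydroxy-3-methoxyphenyl becomes 3,4-dihydroxyphenyl. For the measured compounds named here, no measured pair isolates this change. Compound 3 `COc1cc(/C=N/NC(=O)CCc2nc3ccccc3c(=O)[nH]2)cc(O)c1O`, which has two hydroxy groups on its aromatic ring but a different chain, gives 50000000 nM. Yet compound 1 `COc1cc(/C=N/NC(=O)CCc2nc3ccccc3c(=O)[nH]2)cc(OC)c1OC`, with no hydroxy group, gives 80000000 nM, so the support is weak. The expected change is a 2.2-fold lower number from compound 2 to compound 4 (0.33 log units; beyond the scatter), a modest move toward stronger inhibition. For compound 4 the estimated value is 130000000 nM, with an expected range of 40000000 nM to 350000000 nM.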

Compound 4, half-maximal inhibitory concentration: 75000000 nM
Compound 4: the middle estimate sits 1.7-fold (0.24 log units) above what was measured, within the range that was stated.
By their numbers in this assay, from the lowest: compounds 3, 4 and 1 (each within the scatter of the next); then compound 2.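

In this assay, for the compounds shown here, hydrogen in place of methyl on an oxygen on an aromatic ring gives a 3.7-fold lower number from compound 2 to compound 4 (0.57 log units; beyond the scatter), the first measured pair to isolate this change. At this place, on this chain, going from methoxy to hydroxy therefore moves the number modestly toward stronger inhibition. Nothing at hand accounts for the step.

The compounds shown leave open whether the same change would give a step of like size on the different chain of compound 3. They also leave open how an amine or a carboxylic acid would read at this place.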